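From compound 3 to compound 4: a swapped side chain

The source may report more compounds than this note shows. Statements on the series, on what has been measured and on what is new or still open speak of the compounds shown alone.

compound 1 `COc1ccc(N(C)c2nc(C)nc3ccccc23)cc1C(=O)OCC[Se]C#N` gives 2960 nM
compound 2 `COc1ccc(N(C)c2nc(C)nc3ccccc23)cc1OCCCCCC[Se]C#N` gives 8580 nM
compound 3 `COc1ccc(N(C)c2nc(C)nc3ccccc23)cc1C(=O)NCC[Se]C#N` gives 561 nM

In a functional assay on LoVo cells (Homo sapiens) for inhibition, read by MTT assay, with a stated time of 48 h (on this read-out lower numbers stand for stronger inhibition and higher numbers for weaker inhibition), compound 3 gives the lowest number of the three, 561 nM, and its gaps to both others lie beyond the scatter. That makes it the strongest inhibitor so far.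

Compound 4 `COc1ccc(N(C)c2nc(C)nc3ccccc23)cc1C(=O)OCCCCC[Se]C#N` is still unmeasured. Its change from compound 3 lies on a carbonyl carbon whose other neighbour is an aromatic carbon: a group of 9 heavy atoms (6 carbon, 1 nitrogen, 1 oxygen, 1 selenium; no ring) in place of a group of 6 heavy atoms (3 carbon, 2 nitrogen, 1 selenium; no ring), on a carbonyl carbon. The group that leaves has 1 hydrogen-bond donor, and the group that enters has 0 hydrogen-bond donors.

Two things change at once: the atom linking the chain to the carbonyl carbon goes from nitrogen to oxygen, and the chain grows longer. The closest guide is a pair with the same chain and only that link changed, from oxygen to nitrogen: a 5.3-fold lower number from compound 1 to compound 3 (0.72 log units; beyond the scatter), a modest step. Read backwards, it points to a rise on returning to oxygen. Among the measured compounds shown here, the steps of a 2.9-fold higher number from compound 1 to compound 2 (0.46 log units; beyond the scatter) and a 15-fold lower number from compound 2 to compound 3 (1.18 log units; beyond the scatter) also involve a longer chain, but they alter the link too, so no measured pair shows chain length alone.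

In this assay the expected result is a 5.3-fold higher number from compound 3 to compound 4 (0.73 log units; beyond the scatter), a modest step. The estimate for compound 4 is 3000 nM, with an expected range from 1000 nM to 9000 nM.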

Compound 4, half-maximal inhibitory concentration: 714 nM
Beside the measured number, compound 4's estimate is 4.2-fold (0.62 log units) above it; measured number outside the range, below it.
By their numbers in this assay, from the lowest: compounds 3 and 4 (each within the scatter of the next); then compound 1; then compound 2.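

Compound 1 and compound 4 share the ester link and differ only in chain length, so they give the first measured view of that change alone: in this assay there is a 4.1-fold lower number from compound 1 to compound 4 (0.62 log units; beyond the scatter). This holds for this one ester pair only and cannot be extended to compound 2, whose chain is attached through a different link. The ester no longer trails the amide once its chain is longer, with a 1.3-fold higher number from compound 3 to compound 4 (0.10 log units; within the scatter), so the group with 0 hydrogen-bond donors on the carbonyl carbon reads level with the group that has 1, and the amide hydrogen is not needed for a number in this range; no supporting evidence is available to explain either result.

As far as these compounds go, whether the longer chain of compound 4 would also lower the number when attached through the amide link of compound 3 remains open, as does whether a still longer chain on the ester would lower it further. Also open, from the compounds shown here alone, is how much the selenium itself contributes, which a thiocyanate end, with sulfur in place of selenium, would test.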